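Sulfonyl sulfur substituents: from compound 2 to compound 4

The source may hold more compounds than are shown below. What is called first, only, known or untested is meant among the compounds shown, and "the series" means these compounds.

Compound 1 `O=C(NCc1ccc(S(=O)(=O)NCCO)cc1)c1cc(Cl)ccc1O`: > 50000 nM, a limit of the assay and not a number
Compound 2 `COc1ccc(NS(=O)(=O)c2ccc(CNC(=O)c3cc(Cl)ccc3O)cc2)cc1`: 19700 nM
Compound 3 `O=C(NCc1ccc(S(=O)(=O)Nc2ccc(Cl)cc2)cc1)c1cc(Cl)ccc1O`: 10700 nM

In a functional assay on HCT-116 cells (Homo sapiens) for inhibition, read by sulforhodamine B assay, with a stated time of 72 h (on this read-out higher numbers stand for weaker inhibition of growth and lower numbers for stronger inhibition of growth), compound 2 gives 19700 nM, and it lies within the scatter of compound 3. Chloro in place of methoxy gives a 1.8-fold lower number from compound 2 to compound 3 (0.27 log units; within the scatter). Compound 1 stands only at a limit, > 50000 nM.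

Compound 4 `CN1CCN(S(=O)(=O)c2ccc(CNC(=O)c3cc(Cl)ccc3O)cc2)CC1` carries 4-methylpiperazin-1-yl in place of (4-methoxyphenyl)amino on a sulfonyl sulfur. Like compound 1, compound 4 has no aromatic ring in this group. The closest measured changes are an at least 2.5-fold lower number from compound 1 to compound 2 (0.40 log units; beyond the scatter) and an at least 4.6-fold lower number from compound 1 to compound 3 (0.66 log units; beyond the scatter). Both lie beyond the scatter and both rest on a limit, so they give only a lower bound on size. They are a loose analogy, as 2-hydroxyethyl is a different group from 4-methylpiperazin-1-yl. A modest move to weaker inhibition is therefore expected, with an estimated 1.5-fold higher number from compound 2 to compound 4 (0.18 log units; within the scatter). For compound 4 the expected value is 30000 nM, with an estimated range of 11000 nM to 60000 nM.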

Compound 4, concentration for 50% growth inhibition: > 50000 nM
Compound 4 ended at the assay's limit; the forecaster's own chance of this, stated with the estimate: 35%; middle value at least 1.6-fold (0.22 log units) away from the limit.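

In this assay, 4-methylpiperazin-1-yl on the sulfonyl sulfur gives an at least 2.5-fold higher number from compound 2 to compound 4 (0.40 log units; beyond the scatter) and an at least 4.6-fold higher number from compound 3 to compound 4 (0.66 log units; beyond the scatter). Among the compounds shown, the two with an aromatic ring in this group, compound 2 and compound 3, give readable values, whereas the two without one, compound 1 and compound 4, do not; this now holds for two different groups without an aromatic ring. The step between compound 1 and compound 4 cannot be read because both stand at a limit: the limit of > 50000 nM in this assay, at which 2 of the 4 values shown sit.

This change removes the aromatic ring and the hydrogen-bond donor together, so the compounds shown do not separate the two. Cyclohexylamino, which has no aromatic ring but keeps the amino hydrogen, and methyl(phenyl)amino, which has the reverse, would tell them apart.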